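Benzyl ester in place of methyl ester on two cores

This account rests on a few compounds, and the source may have more. Where it says the series, first, only, none or still open, it means among the compounds named here.

Measured compounds:
Compound 1, `C=C1CC[C@H]2[C@@](C)(CC[C@@H](OC(C)=O)[C@@]2(C)C(=O)OC)[C@@H]1CCC1=CCOC1=O`: 80600 nM
Compound 2, `C=C1CC[C@H]2[C@@](C)(CC[C@@H](OC(C)=O)[C@@]2(C)C(=O)OCc2ccccc2)[C@@H]1CCC1=CCOC1=O`: 12900 nM
Compound 3, `C=C1CC[C@H]2[C@@](C)(CC[C@@H](O)[C@@]2(C)C(=O)OC)[C@@H]1/C=C/C1=CCOC1=O`: 111000 nM

All three were tested in a functional assay on NIH3T3 cells (Mus musculus) for inhibition, read by MTT assay, with a stated time of 72 h; a higher number here means a weaker inhibitor, a lower number a stronger inhibitor. Compound 1 has the structure `C=C1CC[C@H]2[C@@](C)(CC[C@@H](OC(C)=O)[C@@]2(C)C(=O)OC)[C@@H]1CCC1=CCOC1=O` and gives 80600 nM in this assay. Compound 2, `C=C1CC[C@H]2[C@@](C)(CC[C@@H](OC(C)=O)[C@@]2(C)C(=O)OCc2ccccc2)[C@@H]1CCC1=CCOC1=O`, differs from compound 1 by phenyl in place of hydrogen on a saturated chain carbon bound to an oxygen next to a carbonyl group. In this assay compound 2 gives 12900 nM, a step of a 6.2-fold lower number from compound 1 to compound 2 (0.80 log units; beyond the scatter). Compound 3, `C=C1CC[C@H]2[C@@](C)(CC[C@@H](O)[C@@]2(C)C(=O)OC)[C@@H]1/C=C/C1=CCOC1=O`, gives 111000 nM; how its core differs from that of compound 1 is not broken down here.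

Compound 4, `C=C1CC[C@H]2[C@@](C)(CC[C@@H](O)[C@@]2(C)C(=O)OCc2ccccc2)[C@@H]1/C=C/C1=CCOC1=O`, has not yet been measured. It stands to compound 3 as compound 2 stands to compound 1: phenyl in place of hydrogen on a saturated chain carbon bound to an oxygen next to a carbonyl group. The place is the same in both pairs, so the change is the same one made on a different core. If it carries over, compound 4 is expected to show a step of about a 6.2-fold lower number from compound 3 to compound 4 (0.79 log units; beyond the scatter) in this assay, resting on the single earlier step of a 6.2-fold lower number from compound 1 to compound 2 (0.80 log units; beyond the scatter). Compound 4 is therefore estimated at 18000 nM, within a range of 7000 nM to 45000 nM.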

Compound 4, half-maximal inhibitory concentration: 13600 nM
Compound 4: middle estimate off by 1.3-fold (0.12 log units), on the high side, and the stated range covers the measured number.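

In this assay, the change from methoxycarbonyl to benzyloxycarbonyl on the core of compound 3 gives an 8.2-fold lower number from compound 3 to compound 4 (0.91 log units; beyond the scatter), so the drop seen on the core of compound 1 appears again on a second core. The two steps run the same way and cannot be told apart in size: the same change on two cores in this assay, a 6.2-fold lower number (0.80 log units; beyond the scatter) from compound 1 to compound 2 and an 8.2-fold lower number (0.91 log units; beyond the scatter) from compound 3 to compound 4, 1.3-fold (0.12 log units) apart, within the scatter of two such steps

For the compounds shown here, this shows that, across these two pairs, the effect of the change carries over from one core to the other, but it rests on only two cores in a single assay and does not show that it would hold on any further core or explain why the number falls.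

The compounds shown leave open whether the phenyl ring itself matters or whether a longer chain ester, such as a butyl ester, would give a similar step. They also leave open how a free carboxylic acid or an amide at the same place would compare, and whether a substituent on the phenyl ring, such as fluorine, would alter the step.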